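The source may report more compounds than this note shows. Statements on the series, on what has been measured and on what is new or still open speak of the compounds shown alone.

Measured so far:
Compound 1 `O=C(N/N=C\c1ccc(Oc2ccc(Cl)cc2)cc1)c1ccncc1`: 3.95
Compound 2 `O=C(N/N=C\c1ccc(Oc2ccc([N+](=O)[O-])cc2)cc1)c1ccncc1`: 3.23

Among the measured compounds shown here, in a physicochemical assay for lipophilicity, in phosphate buffer, measured as octanol-water partition, with a stated time of 24 h (a higher number here means a more lipophilic compound, a lower number a more polar compound), compound 1 stands highest of the two numbers; its only neighbour is compound 2, and the step of a number 0.72 log units lower from compound 1 to compound 2 (beyond the scatter) came with a nitro in place of a chloro on an aromatic carbon. Compound 3 `O=C(N/N=C\c1ccc(Oc2ccc(Br)cc2)cc1)c1ccncc1` differs from compound 1 in another way: bromo in place of chloro on an aromatic carbon. For the measured compounds named here, no measured step swaps one halogen for another, so the nitro step offers no direct guide. Halogen for halogen is a small change, and compound 3 is expected to stay close to compound 1, a step of a number 0.15 log units higher from compound 1 to compound 3 (within the scatter) within the scatter. The estimate for compound 3 is 4.1, ranging from 3.8 to 4.4.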

Compound 3, partition coefficient: 4.03
Compound 3: the middle estimate sits 0.07 log units above what was measured; the measured number falls inside the stated range.
By their numbers in this assay, from the lowest: compound 2; then compounds 1 and 3 (each within the scatter of the next).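

In this assay, bromo in place of chloro gives a number 0.08 log units higher from compound 1 to compound 3 (within the scatter) and so, at this place on the aromatic ring, swapping one of these two halogens for the other leaves compounds 1 and 3 indistinguishable. Bromo in place of nitro gives a number 0.80 log units higher from compound 2 to compound 3 (beyond the scatter) and so compound 2 stands apart from both halogen compounds. Nothing measured here explains either step.

On these data alone, whether fluoro would also stay as close to compound 1 remains open. So does how far an amine or a carboxylic acid at this place would shift the number.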